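A Fluoropyridine for a Phenyl on an Inactive Scaffold

The source may hold more compounds than are shown below. What is called first, only, known or untested is meant among the compounds shown, and "the series" means these compounds.

Compound 1 `N#Cc1ccc(N2CCc3cc(-c4cncnc4)ccc32)cc1C(F)(F)F`: "not determined" (no result reported)
Compound 2 `CCN(c1ccc(C#N)c(Cl)c1)c1cc(-c2ccccc2)ccc1C`: > 30000 nM
Compound 3 `CCN(c1cccc(-c2ccccc2)c1)c1ccc(C#N)c(Cl)c1`: "not determined" (no result reported)

Only compound 2 carries a result in a functional assay on CWR22R cells (Homo sapiens) for antiproliferative activity, read by CCK-8 assay, with a stated time of 6 days; on this read-out higher numbers stand for weaker inhibition and lower numbers for stronger inhibition. Compound 2 gives > 30000 nM, which is a limit of the assay and not a number, and it stands at the limit of > 30000 nM in this assay, at which 1 of the 3 values shown sits. Within the data shown here, compound 1 and compound 3 have no result in this assay, so no step between two measured compounds can serve as a guide.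

Compound 4 is `CCN(c1ccc(C#N)c(Cl)c1)c1cc(-c2ccc(F)nc2)ccc1C`. Compared with compound 2 the change is 6-fluoropyridin-3-yl in place of phenyl on an aromatic carbon. With nothing measured to lean on, the expected step from compound 2 to compound 4 is an at least 1.2-fold lower number from compound 2 to compound 4 (0.07 log units; that floor lies within the scatter), and a second limit is quite possible. Compound 4 is therefore estimated at about 25000 nM, within a range from 5000 nM to 60000 nM.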

Compound 4, half-maximal inhibitory concentration: 16500 nM
Estimate against measurement, compound 4: 1.5-fold (0.18 log units) above; low and high end bracket the measured number.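

In this assay compound 4 is the only compound shown with a single number, so 6-fluoropyridin-3-yl in place of phenyl at this position brings the read-out within the range of the assay. The change gives an at least 1.8-fold lower number from compound 2 to compound 4 (0.25 log units; that floor lies within the scatter) and that is only a floor. Its true size cannot be read because compound 2 stands at a limit and not at a number: the limit of > 30000 nM in this assay, at which 1 of the 4 values shown sits.

On these data alone, whether the ring nitrogen or the fluorine matters more stays open. So does the result of a pyridin-3-yl without fluorine, or of an amine or a carboxylic acid on the ring here.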